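This account rests on a few compounds, and the source may have more. Where it says the series, first, only, none or still open, it means among the compounds named here.

Two compounds of this series share one core and differ from each other in two places. Compound 1 `CN(C)CCCNc1nc(-c2ccc(NC(=O)Nc3ccccc3Cl)cc2)nc2c(Cl)c(Cl)sc12` carries a dimethylamino-terminated chain together with a 2-chlorophenyl urea; in a functional assay on MDA-MB-231 cells (Homo sapiens) for cytotoxicity, read by MTT assay, with a stated time of 72 h (on this read-out lower numbers stand for stronger inhibition and higher numbers for weaker inhibition), compound 1 gives 1560 nM. Compound 2 `CCN(CC)CCCNc1nc(-c2ccc(NC(=O)Nc3ccc(F)cc3)cc2)nc2c(Cl)c(Cl)sc12` carries a diethylamino-terminated chain together with a 4-fluorophenyl urea; in this assay compound 2 gives 1630 nM. The two numbers sit side by side within the scatter, so compound 2 cannot be set apart from compound 1 on this read-out. Compound 3 `CCN(CC)CCCNc1nc(-c2ccc(NC(=O)Nc3ccccc3Cl)cc2)nc2c(Cl)c(Cl)sc12` has not been measured. It keeps the chain of compound 2 and takes the urea end of compound 1: 2-chlorophenyl in place of 4-fluorophenyl on an amide-type nitrogen. For the measured compounds named here, no measured pair shows this exchange on its own. Because compound 1 with 2-chlorophenyl gives 1560 nM and compound 2 gives 1630 nM, no step beyond the scatter is expected in this assay in either direction. The step from compound 2 to compound 3 is expected to be a 1.1-fold lower number from compound 2 to compound 3 (0.04 log units; within the scatter). Compound 3 is therefore estimated at 1500 nM, with a range from 700 nM to 3200 nM.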

Compound 3, half-maximal inhibitory concentration: 970 nM
Compound 3: the middle estimate sits 1.5-fold (0.19 log units) above what was measured, within the range that was stated.
By their numbers in this assay, from the lowest: compounds 3, 1 and 2 (each within the scatter of the next).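

For the compounds shown here, with compound 3, the series gains pairs that differ in only one place, so each end of the molecule can be read on its own in this assay for the first time. On an amide-type nitrogen, 2-chlorophenyl in place of 4-fluorophenyl gives a 1.7-fold lower number from compound 2 to compound 3 (0.23 log units; within the scatter) as its step, while diethylamino in place of dimethylamino on a saturated chain carbon, three bonds along the chain from a nitrogen on an aromatic ring, gives a 1.6-fold lower number from compound 1 to compound 3 (0.21 log units; within the scatter) as its step, so neither single exchange sets its two compounds apart on this read-out. Nothing measured here bears on what lies behind these numbers.

The compounds shown leave open whether another group on the urea nitrogen, such as unsubstituted phenyl or 4-chlorophenyl, would give a step beyond the scatter, and they cannot separate the effect of the chlorine from that of where it sits. They also leave open whether a ring amine such as morpholine or pyrrolidine at the end of the chain, or a longer chain, would move the number in this assay any further.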